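Replacing a methyl with a hydroxylated branch: expected solubility

The source may report more compounds than this note shows. Statements on the series, on what has been measured and on what is new or still open speak of the compounds shown alone.

compound 1 `Cc1c(-c2ccccc2)c(N2CC[C@H](N(C)C)C2)n2cc(C(C)(C)C)nc2c1C#N`: 27 ug/mL
compound 2 `Cc1c(-c2ccccc2)c(N2CC[C@H](N(C)C)C2)n2nc(C(C)(C)COCc3ccccc3)nc2c1C#N`: a limit, < 3 ug/mL
compound 3 `Cc1nc2c(C#N)c(C)c(-c3ccccc3)c(N3CC[C@H](N(C)C)C3)n2n1`: 376 ug/mL

In a physicochemical assay for solubility, at pH 6.8 (on this read-out higher numbers stand for higher solubility and lower numbers for lower solubility), compound 3 stands highest of the two numbers given, with compound 1 as its nearest neighbour. For compound 2 this assay reports only a limit, < 3 ug/mL. Compound 4 `Cc1c(-c2ccccc2)c(N2CC[C@H](N(C)C)C2)n2nc(C(C)(C)CO)nc2c1C#N` differs from compound 3 by 1-(hydroxymethyl)-1-methylethyl in place of methyl on an aromatic carbon. Among the compounds with values here, the only measured step that bears on this change is an at least 120-fold higher number from compound 2 to compound 3 (2.09 log units; beyond the scatter), whose true size is uncertain because the limit of < 3 ug/mL in this assay, at which 1 of the 3 values shown sits, is involved. The present change goes the other way but brings in a far smaller group, so a drop smaller than that step is expected. Compound 4 is therefore estimated at 100 ug/mL, within 20 ug/mL to 400 ug/mL, which means an expected 3.8-fold lower number from compound 3 to compound 4 (0.58 log units; beyond the scatter).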

Compound 4, solubility: 140 ug/mL
Compound 4: middle estimate off by 1.4-fold (0.15 log units), on the low side, and the stated range covers the measured number.
By their numbers in this assay, from the lowest: compound 1; then compound 4; then compound 3. At a limit, below all of these: compound 2.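

In this assay, putting 1-(hydroxymethyl)-1-methylethyl in place of methyl on this aromatic carbon gives a 2.7-fold lower number from compound 3 to compound 4 (0.43 log units; beyond the scatter), so the larger branch can sit here with only a modest change in the number. Placing hydrogen in place of benzyl on the oxygen gives an at least 46-fold higher number from compound 2 to compound 4 (1.66 log units; beyond the scatter), which ties most of the gap seen earlier to the benzyl rather than to the branch itself. Compound 2 gives only a limit, so the true size of that second step is uncertain: the limit of < 3 ug/mL in this assay, at which 1 of the 4 values shown sits.

As far as these compounds go, what an amine or a carboxylic acid at the end of this branch would give stays open, as does the effect of a longer chain.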